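Three Sulfonamides at the Assay Limit and a Chloro Analogue

The source may hold more compounds than are shown below. What is called first, only, known or untested is meant among the compounds shown, and "the series" means these compounds.

Measured compounds:
Compound 1, `COc1ccc(S(=O)(=O)NC2=NCCN2C(=S)SN2CCn3c2nsc3=S)cc1`: >= 20000 nM
Compound 2, `COc1ccc(OC)c(S(=O)(=O)NC2=NCCN2C(=S)SN2CCn3c2nsc3=S)c1`: >= 20000 nM
Compound 3, `O=[N+]([O-])c1ccc(S(=O)(=O)NC2=NCCN2C(=S)SN2CCn3c2nsc3=S)cc1`: >= 20000 nM

In a functional assay on KYSE-510 cells (Homo sapiens) for antiproliferative activity, read by crystal violet staining, with a stated time of 96 h (on this read-out higher numbers stand for weaker inhibition of growth and lower numbers for stronger inhibition of growth), compound 3 gives only a limit, >= 20000 nM, not a number. Compound 1 likewise gives a limit in this assay. Compound 2 also gives a limit in this assay. Because of the limit of >= 20000 nM in this assay, at which 3 of the 3 values shown sit, none of the three steps among them can be read: a step that the two limits leave unreadable from compound 1 to compound 2, a step that the two limits leave unreadable from compound 1 to compound 3 and a step that the two limits leave unreadable from compound 2 to compound 3 are all unreadable in size.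

Compound 4, `O=S(=O)(NC1=NCCN1C(=S)SN1CCn2c1nsc2=S)c1cccc(Cl)c1`, differs from compound 3 by 3-chlorophenyl in place of 4-nitrophenyl on a sulfonyl sulfur. The three measured steps bear on this change only in that every ring so far, methoxy-bearing or nitro-bearing, has left the shared core at the limit in this assay. Among the compounds with values here, no measured step gives a readable size, so no direction beyond the scatter can be expected from them.

Compound 4 is therefore expected to sit near the same limit, at an estimated 20000 nM with a range from 5000 nM to 60000 nM. The step from compound 3 to compound 4 is thus estimated as a number no higher from compound 3 to compound 4 (the limit leaves the size open).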

Compound 4, concentration for 50% growth inhibition: >= 20000 nM
Compound 4: no number, only a limit; the forecaster's own chance of this, stated with the estimate: 75%; the middle value sits exactly at the limit.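

In this assay compound 4 gives >= 20000 nM which is a limit and not a number. Its steps from compound 1, compound 2 and compound 3 cannot be read, because all four share one limit: the limit of >= 20000 nM in this assay, at which 4 of the 4 values shown sit. The compounds shown leave open how strongly any of them inhibits growth, and whether changing the ring on the sulfonyl sulfur alters that.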